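The source may hold more compounds than are shown below. What is called first, only, known or untested is meant among the compounds shown, and "the series" means these compounds.

Compound 1 `COc1ncc(-c2ccc3ncc(NC(=O)C4CCCCC4)c(OC)c3c2)cc1NS(=O)(=O)c1ccc(F)cc1F` gives 6630 nM
Compound 2 `COc1ncc(-c2ccc3ncc(NCC4CCCCC4)c(OC)c3c2)cc1NS(=O)(=O)c1ccc(F)cc1F` gives 9000 nM

In a functional assay on PC-3 cells (Homo sapiens) for antiproliferative activity, read by sulforhodamine B assay, with a stated time of 72 h (on this read-out lower numbers stand for stronger inhibition and higher numbers for weaker inhibition), compound 2 gives 9000 nM, level with compound 1 within the scatter. Compound 3 `COc1ccc(CNc2cnc3ccc(-c4cnc(OC)c(NS(=O)(=O)c5ccc(F)cc5F)c4)cc3c2OC)cc1` differs from compound 2 in one place 4-methoxyphenyl in place of cyclohexyl on a saturated chain carbon bound to a nitrogen on an aromatic ring with 4-methoxyphenyl in place of cyclohexyl on a saturated chain carbon bound to a nitrogen on an aromatic ring. Among the compounds with values here, the only measured step, which also changes a group on that nitrogen, is small (a 1.4-fold higher number from compound 1 to compound 2 (0.13 log units; within the scatter)) and no measured step covers this swap itself. No step beyond the scatter is therefore expected in this assay, and the estimated step is small (a 1.1-fold lower number from compound 2 to compound 3 (0.05 log units; within the scatter)). For compound 3 the expected value is 8000 nM, with an estimated range from 3000 nM to 20000 nM.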

Compound 3, half-maximal inhibitory concentration: 4520 nM
Estimate against measurement, compound 3: 1.8-fold (0.25 log units) above; low and high end bracket the measured number.
By their numbers in this assay, from the lowest: compounds 3, 1 and 2 (each within the scatter of the next).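

In this assay, an aromatic ring on this chain reads the same as a saturated one: 4-methoxyphenyl in place of cyclohexyl gives a 2.0-fold lower number from compound 2 to compound 3 (0.30 log units; within the scatter), and 4-methoxybenzyl in place of cyclohexylcarbonyl gives a 1.5-fold lower number from compound 1 to compound 3 (0.17 log units; within the scatter). Neither step lies beyond the scatter, so all three groups on this nitrogen stay level, with or without the carbonyl. No evidence is available that bears on this result. On these data alone, whether a terminal amine, a carboxylic acid or a longer chain at this place would give a step beyond the scatter stays open.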